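Aryl-to-alkyl change on the urea nitrogen of the series

A few compounds are considered here, and "the series" means these few. Any claim that something is new, unique, unknown or untested is made for them only; others in the source may bear on it.

Measured so far, in an assay on isolated protein for inhibition of histamine H2 receptor (Cavia porcellus); a higher number here means weaker binding, a lower number tighter binding:
compound 1, `O=C(NCCCOc1cccc(CN2CCCCC2)c1)Nc1cccc(C(F)(F)F)c1`, 813 nM
compound 2, `Cc1ccc(NC(=O)NCCCOc2cccc(CN3CCCCC3)c2)cc1`, 631 nM

Compound 2 stands level with compound 1 on the numbers shown: the step of a 1.3-fold lower number from compound 1 to compound 2 (0.11 log units; within the scatter) lies within the scatter, so neither compound can be ranked against the other. Compound 3, `CCC(C)NC(=O)NCCCOc1cccc(CN2CCCCC2)c1`, is not yet measured. It differs from compound 2 in one place: sec-butyl in place of 4-methylphenyl on an amide-type nitrogen. Among the measured compounds shown here, the one measured step, a 1.3-fold lower number from compound 1 to compound 2 (0.11 log units; within the scatter), exchanges one aryl group for another and bears on the new change only loosely; it shows that the two aryl groups are interchangeable within the scatter, but nothing measured so far tells how an alkyl group on that nitrogen behaves. No firm direction follows from the data. The working expectation for compound 3 is a modest weakening, a 2.4-fold higher number from compound 2 to compound 3 (0.38 log units; beyond the scatter), carried with a wide range. The anchor is compound 2 with its 631 nM. Compound 3 is therefore estimated at 1500 nM in this assay, with a range from 400 nM to 5000 nM.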

Compound 3, dissociation constant: 95.5 nM
Compound 3: middle estimate off by 16-fold (1.20 log units), on the high side, and the stated range ends above it.
By their numbers in this assay, from the lowest: compound 3; then compounds 2 and 1 (each within the scatter of the next).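

In this assay, sec-butyl on the amide-type nitrogen gives a 6.6-fold lower number from compound 2 to compound 3 (0.82 log units; beyond the scatter) and, set against the other aryl group, an 8.5-fold lower number from compound 1 to compound 3 (0.93 log units; beyond the scatter). This position therefore responds clearly to the group it carries, which the level pair of 4-methylphenyl and 3-(trifluoromethyl)phenyl could not show: among the three compounds, the one without an aryl ring at this nitrogen, with 4 heavy atoms in place of 7 in the 4-methylphenyl group, binds tightest, and neither aryl compound goes against this. No measurement on hand accounts for the tighter binding.

With sec-butyl the only alkyl group shown on this nitrogen, it remains open whether the gain extends to alkyl groups in general or belongs to this one group. An n-butyl chain, a tert-butyl group, a cyclohexyl ring or a benzyl group in the same place would help separate the loss of the aromatic ring from the shape and size of the alkyl group, and would show how far the gain can be carried.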